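The source may hold more compounds than are shown below. What is called first, only, known or untested is meant among the compounds shown, and "the series" means these compounds.

Measured compounds:
Compound 1, `CCn1c(-c2ccc(OCc3c(-c4c(Cl)cccc4Cl)noc3C(C)C)cc2)nc2ccc(C(=O)O)cc21`: 5760 nM
Compound 2, `CC(C)c1onc(-c2c(Cl)cccc2Cl)c1COc1ccc(-c2nc3ccc(C(=O)O)cc3n2C(C)C)cc1`: 3550 nM

Going by the values given here, in an assay on HEK-293T cells for antagonist activity at vitamin D3 receptor (Homo sapiens), read by a luciferase reporter, with a stated time of 24 h (on this read-out higher numbers stand for weaker inhibition and lower numbers for stronger inhibition), compound 2 gives 3550 nM, and its only neighbour on this read-out is compound 1, which gives 5760 nM in this assay. Among the compounds with values here, the one measured step, a 1.6-fold lower number from compound 1 to compound 2 (0.21 log units; within the scatter), does not separate the two compounds beyond the usual scatter.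

Compound 3, `CC(C)c1onc(-c2c(Cl)cccc2Cl)c1COc1ccc(-c2nc3ccc(C(=O)O)cc3n2C2CCCCC2)cc1`, has not yet been measured in this assay. It differs from compound 2 by cyclohexyl in place of isopropyl on an aromatic nitrogen. Within the data shown here, the only step that bears on this change is a 1.6-fold lower number from compound 1 to compound 2 (0.21 log units; within the scatter), which enlarged the group on the same aromatic nitrogen and stayed within the scatter. Compound 3 enlarges that group again, so a small shift toward a lower number is expected, but nothing that clearly exceeds the scatter.

The estimate for compound 3 in this assay is 2500 nM, expected to lie between 800 nM and 8000 nM, which means an expected step of a 1.4-fold lower number from compound 2 to compound 3 (0.15 log units; within the scatter).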

Compound 3, half-maximal inhibitory concentration: 1450 nM
Beside the measured number, compound 3's estimate is 1.7-fold (0.24 log units) above it; the range from low to high includes it.
By their numbers in this assay, from the lowest: compound 3; then compounds 2 and 1 (each within the scatter of the next).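

Among the compounds shown, the group on this aromatic nitrogen first moves the number beyond the scatter in this assay with cyclohexyl in place of isopropyl (a 2.4-fold lower number from compound 2 to compound 3 (0.39 log units; beyond the scatter)), and cyclohexyl in place of ethyl gives a larger step (a 4.0-fold lower number from compound 1 to compound 3 (0.60 log units; beyond the scatter)). Compound 3 is therefore the strongest inhibitor of the three, while ethyl and isopropyl remain within the scatter of each other. No measurement shown here explains why this position responds to the change.

Cyclohexyl differs from isopropyl both in its carbon count and in carrying a ring, so these compounds cannot tell which of the two goes with the lower number. On these data alone, whether an open hexyl chain or a phenyl group on the same nitrogen would match cyclohexyl also remains open.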